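This account rests on a few compounds, and the source may have more. Where it says the series, first, only, none or still open, it means among the compounds named here.

In a functional assay for agonist activity at P2Y purinoceptor 2 (Homo sapiens), read by FLIPR (on this read-out lower numbers stand for an effect already at smaller amounts and higher numbers for an effect only at larger amounts of compound), compound 1 `O=c1c2ccsc2ccn1[C@@H]1O[C@H](COP(=O)(O)OP(=O)(O)OP(=O)(O)O)[C@@H](O)[C@H]1O` gives 30 nM and compound 2 `Cc1ccc2c(=O)n([C@@H]3O[C@H](COP(=O)(O)OP(=O)(O)OP(=O)(O)O)[C@@H](O)[C@H]3O)ccc2c1` gives 35 nM; these two numbers lie within the usual scatter of each other. Compound 3 `Cc1ccc2ccn([C@@H]3O[C@H](COP(=O)(O)OP(=O)(O)OP(=O)(O)O)[C@@H](O)[C@H]3O)c(=O)c2c1` gives 148 nM in this assay, the highest of the three numbers, and its distance from each of the other two is beyond the scatter. Compound 4 `CS(=O)(=O)c1ccc2ccn([C@@H]3O[C@H](COP(=O)(O)OP(=O)(O)OP(=O)(O)O)[C@@H](O)[C@H]3O)c(=O)c2c1` differs from compound 3 by methylsulfonyl in place of methyl on an aromatic carbon. Within the data shown here, no measured pair shows this change, so its effect in this assay is unknown; a modest step is expected, in either direction, possibly within the scatter. Compound 4 is therefore estimated at 180 nM, with a range from 50 nM to 650 nM. The expected step is a 1.2-fold higher number from compound 3 to compound 4 (0.09 log units; within the scatter).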

Compound 4, half-maximal effective concentration: 650 nM
Compound 4: middle estimate off by 3.6-fold (0.56 log units), on the low side, and the stated range covers the measured number.
By their numbers in this assay, from the lowest: compounds 1 and 2 (each within the scatter of the next); then compound 3; then compound 4.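

In this assay, methylsulfonyl in place of methyl on this aromatic carbon comes with a 4.4-fold higher number from compound 3 to compound 4 (0.64 log units; beyond the scatter), so the read-out at this position does respond to the group it carries. The earlier compounds shown here could not show this, as no two of them differed in one place. Nothing measured here accounts for the step.

As far as these compounds go, it remains open whether an amine or a carboxylic acid on this carbon would stay near compound 3 or move as far as compound 4. Also open, from the compounds shown here alone, is whether the same change on the methyl-bearing carbon of compound 2 would bring a step of similar size.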